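Furan-to-thiophene swap at the ring nitrogen position

A few compounds are considered here, and "the series" means these few. Any claim that something is new, unique, unknown or untested is made for them only; others in the source may bear on it.

Measured so far:
compound 1 `Oc1ccc(-c2cc(-c3ccsc3)nc(-c3cccc(Cl)c3)c2)cc1`: 6220 nM
compound 2 `Oc1cccc(-c2cc(-c3ccsc3)nc(-c3ccccc3Cl)c2)c1`: 1970 nM
compound 3 `Oc1ccc(-c2cc(-c3ccco3)nc(-c3ccccc3Cl)c2)cc1`: 5300 nM

All three compounds share one core and were tested in a functional assay on DU-145 cells (Homo sapiens) for cytotoxicity, read by CCK-8 assay and cell counting, with a stated time of 2 days; on this read-out lower numbers stand for stronger inhibition and higher numbers for weaker inhibition. Compound 3 `Oc1ccc(-c2cc(-c3ccco3)nc(-c3ccccc3Cl)c2)cc1` stands second highest of the three numbers with 5300 nM. Its nearest neighbour is compound 1, which gives 6220 nM, a gap that lies within the scatter; the furthest is compound 2, which gives 1970 nM, a gap beyond the scatter. Among the compounds with values here, no pair of measured compounds differs in a single place, so no measured step is available to lean on.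

Compound 4 `Oc1ccc(-c2cc(-c3ccsc3)nc(-c3ccccc3Cl)c2)cc1` is not yet measured. It differs from compound 3 in one place: thiophen-3-yl in place of furan-2-yl on an aromatic carbon. The group leaving and the group entering are both five-membered aromatic rings with one hetero atom, equal in heavy-atom count and in hydrogen-bond acceptor count, differing only in the hetero atom itself. Compound 1 and compound 3 also carry different five-membered rings and sit within the scatter of each other, though they differ elsewhere as well, so they are no direct guide.

The step of a 1.2-fold lower number from compound 3 to compound 4 (0.07 log units; within the scatter) is expected to be small, not clearly beyond the scatter in either direction. Compound 4 is therefore estimated at 4500 nM, with a range from 1800 nM to 11000 nM.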

Compound 4, half-maximal inhibitory concentration: 3890 nM
Compound 4: the middle estimate sits 1.2-fold (0.06 log units) above what was measured; low and high end bracket the measured number.
By their numbers in this assay, from the lowest: compounds 2, 4, 3 and 1 (each within the scatter of the next, the first and the last beyond it).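

In this assay, within the data shown here, compound 4 gives the first single-place pairs, and all three steps stay within the scatter: thiophen-3-yl in place of furan-2-yl next to the ring nitrogen gives a 1.4-fold lower number from compound 3 to compound 4 (0.13 log units; within the scatter) while 2-chlorophenyl in place of 3-chlorophenyl gives a 1.6-fold lower number from compound 1 to compound 4 (0.20 log units; within the scatter) and 4-hydroxyphenyl in place of 3-hydroxyphenyl gives a 2.0-fold higher number from compound 2 to compound 4 (0.30 log units; within the scatter). At the position next to the ring nitrogen, this exchange of one five-membered aromatic ring for another therefore does not separate compound 3 from compound 4, although the hetero atom and the point of attachment both differ. No measurement at hand explains the size of any of these steps.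

From the compounds shown here alone, the pair cannot separate the effect of the hetero atom from that of the point of attachment, so a comparison of furan-2-yl with thiophen-2-yl remains open. Also open, going by these compounds, is whether this position tolerates groups outside the five-membered aromatic rings, such as an amine, a carboxylic acid or a longer alkyl chain, to the same extent in this cell read-out.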